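This account rests on a few compounds, and the source may have more. Where it says the series, first, only, none or still open, it means among the compounds named here.

Three compounds sharing one core and differing on an amine nitrogen have been measured so far. In an in vitro ADME assay on microsomes from liver (Mus musculus) for metabolic stability, read by LC-MS (a higher number here means that the compound lasts longer, a lower number that the compound disappears faster), compound 1 `CON/C(=N\C1=NC(=O)C(=O)N1C(C)C)Nc1ccc(Cl)c(Cl)c1` gives > 1 h as a limit of the assay. Compound 2 `CC(C)N1C(=O)C(=O)N=C1/N=C(/Nc1ccc(Cl)c(Cl)c1)NC(C)(C)C` gives > 1 h which is also a limit. Compound 3 `CC(C)N1C(=O)C(=O)N=C1/N=C(\NCC(C)(C)C)Nc1ccc(Cl)c(Cl)c1` gives > 1 h and this too is a limit. The set therefore stands at the limit of > 1 h in this assay, at which 3 of the 3 values shown sit, and compound 3 has no exact place within it.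

The next compound is compound 4 `CC(C)N1C(=O)C(=O)N=C1/N=C(\NCCCN(C)C)Nc1ccc(Cl)c(Cl)c1` which carries 2-(dimethylamino)ethyl in place of tert-butyl on a saturated chain carbon bound to an amine nitrogen and so turns neopentyl into 3-(dimethylamino)propyl. The measured steps that bear on this change are all changes on that same amine nitrogen. They are a step that the two limits leave unreadable from compound 1 to compound 3 and a step that the two limits leave unreadable from compound 2 to compound 3 and also a step that the two limits leave unreadable from compound 1 to compound 2 and none of them has a readable size. They offer no direction for the new change, so no step beyond the scatter is expected in this assay and the estimate stays close to the limit. The expected change is a step that the limit leaves unreadable from compound 3 to compound 4 as a rough estimate only. For compound 4 the expected half-life is 1.3 h with an estimated range from 0.5 h to 3.5 h as its ends.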

Compound 4, half-life: > 1 h
Compound 4 gave a limit, no number; the forecaster's own chance of this, stated with the estimate: 60%; the middle value does not contradict the limit.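

In this assay compound 4 gives > 1 h, which is a limit of the assay. Within the data shown here, no step from compound 1, compound 2 or compound 3 to compound 4 can be read, because the whole set sits at one limit: the limit of > 1 h in this assay, at which 4 of the 4 values shown sit. The compounds shown leave open what the actual half-life of each of them is, and so whether the groups on the amine nitrogen differ at all.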